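The compounds below may be only part of what the source reports. "The series", "measured", "known", "first", "only" and "open" are said of these compounds alone.

Of the compounds shown here, two sharing one core have been measured so far. Compound 1 `C[C@@H](O)[C@H]1C(=O)N2C(C(=O)O)=C(C(C)(C)C)O[C@H]12` and compound 2 `C[C@@H](F)[C@H]1C(=O)N2C(C(=O)O)=C(C(C)(C)C)O[C@H]12` differ only on the saturated chain carbon that sits on the four-membered ring. In an ADME assay, in phosphate buffer, at 28 degrees C, at pH 7.0 (on this read-out higher numbers stand for a longer-lived compound and lower numbers for a shorter-lived compound), compound 1 gives 8.1 h. In this assay compound 2 gives 3.5 h, the lower of the two numbers; the change a 2.3-fold lower number from compound 1 to compound 2 (0.36 log units; beyond the scatter) lies beyond the scatter, so compound 2 is the shorter-lived of the pair.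

Compound 3 `CC(=O)NC[C@H]1C(=O)N2C(C(=O)O)=C(C(C)(C)C)O[C@H]12` is the next member, not yet measured in this assay. It differs from compound 2 in one place: acetamidomethyl in place of 1-fluoroethyl on a saturated ring carbon. For the measured compounds named here, the only measured step, a 2.3-fold lower number from compound 1 to compound 2 (0.36 log units; beyond the scatter), swapped a single atom on that same chain, whereas here the whole chain changes, so it bears only loosely on the new step. Going by the values given here, compound 3 is therefore expected to land somewhere between the two known numbers, with the step of a 1.6-fold higher number from compound 2 to compound 3 (0.20 log units; within the scatter) estimated as modest and upward. The estimate for compound 3 is 5.5 h, with a range from 2.5 h to 12 h.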

Compound 3, half-life: < 3 h
Compound 3: only a limit was reported; the forecaster's own chance of this, stated with the estimate: 0%; middle value at least 1.8-fold (0.26 log units) from the limit.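

In this assay compound 3 gives a limit, not a number: the limit of < 3 h in this assay, at which 1 of the 3 values shown sits.

Even so, the limit can be read against the hydroxy-bearing chain: there is an at least 2.7-fold lower number from compound 1 to compound 3 (0.43 log units; beyond the scatter), so on this saturated ring carbon, replacing 1-hydroxyethyl with acetamidomethyl gives a shorter-lived compound. Against 1-fluoroethyl the reading is weaker: the step is an at least 1.1-fold lower number from compound 2 to compound 3 (0.06 log units; that floor lies within the scatter), and with that floor within the scatter, the data do not separate these two chains.

On these data alone, the actual half-life of compound 3 remains open, so the full size of both steps is unknown. As far as these compounds go, it is also open whether a free amine in place of the acetamide, or a longer chain at this ring carbon, would keep the compound as long-lived as compound 1.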